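The source may hold more compounds than are shown below. What is called first, only, known or untested is meant among the compounds shown, and "the series" means these compounds.

Compound 1 `C/C(=N\NC(N)=O)c1ccc2c(c1)nc(-c1ccc(Cl)cc1)n2C1CCCCC1`: in an ADME assay on MDBK cells (Bos taurus) for cytotoxicity, read by MTT assay, with a stated time of 96 h (on this read-out higher numbers stand for lower toxicity in this test and lower numbers for higher toxicity in this test), compound 1 gives > 100000 nM, which is a limit of the assay rather than a number.
Compound 2 `C/C(=N\NC(N)=O)c1ccc2c(c1)nc(-c1ccc(C(F)(F)F)cc1)n2C1CCCCC1`: compound 2 gives > 100000 nM, likewise a limit.
Compound 3 `C/C(=N\NC(N)=S)c1ccc2c(c1)nc(-c1ccc(Cl)cc1)n2C1CCCCC1`: compound 3 gives > 100000 nM, also a limit.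

Compound 1 and compound 2 differ by trifluoromethyl in place of chloro on an aromatic carbon. In this assay that change gives a step that the two limits leave unreadable from compound 1 to compound 2. Compound 3 carries a different core from compound 1: a group of 3 heavy atoms (1 carbon, 1 nitrogen, 1 sulfur; no ring) in place of a group of 3 heavy atoms (1 carbon, 1 nitrogen, 1 oxygen; no ring), on an amine nitrogen. Compound 4 `C/C(=N\NC(N)=S)c1ccc2c(c1)nc(-c1ccc(C(F)(F)F)cc1)n2C1CCCCC1` remains to be measured; it differs from compound 3 by trifluoromethyl in place of chloro on an aromatic carbon, the same change that separates compound 1 from compound 2, at the same place. Because of the limit of > 100000 nM in this assay, at which 3 of the 3 values shown sit, the expected step is a step that the limit leaves unreadable from compound 3 to compound 4, set beside a step that the two limits leave unreadable from compound 1 to compound 2. Compound 4 is expected to give 150000 nM, most likely again as a limit rather than a number.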

Compound 4, half-maximal cytotoxic concentration: > 100000 nM
Compound 4: a limit, no number; the forecaster's own chance of this, stated with the estimate: 85%; the middle value is on the limit's open side.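

No step can be read between compound 1, compound 2, compound 3 and compound 4, because each gives a limit rather than a number: the limit of > 100000 nM in this assay, at which 4 of the 4 values shown sit.

Left open is how toxic these four compounds actually are to the cells, and whether either change alters that toxicity.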